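The compounds below may be only part of what the source reports. "The series", "measured", "known", "first", "only" and "open" are said of these compounds alone.

Measured so far in a functional assay on U-87MG ATCC cells for cytotoxicity against U-87 MG (Homo sapiens), read by MTT assay, with a stated time of 72 h; a higher number here means a weaker inhibitor, a lower number a stronger inhibitor:
compound 1 `COc1ccc2nc(NC(=O)c3cn(-c4ccccc4)nc3-c3ccc(Cl)cc3)sc2c1` gives 21200 nM;
compound 2 `COc1ccc(-c2nn(-c3ccccc3)cc2C(=O)Nc2nc3ccc(Cl)cc3s2)cc1` gives 8710 nM.

Compound 2 holds the lower of the two numbers; compound 1 stands higher by a margin beyond the scatter. These two differ in more than one place, so no single step can be read between them. Compound 3 `COc1ccc(-c2nn(-c3ccccc3)cc2C(=O)Nc2nc3ccc(OC)cc3s2)cc1` is not yet measured. It takes from compound 2 the change (methoxy in place of chloro on an aromatic carbon). Compound 1 also carries methoxy on the same fused ring and gives 21200 nM, the weaker number. A modest weakening is expected in this assay, the step of a 1.7-fold higher number from compound 2 to compound 3 (0.24 log units; within the scatter) lying near the edge of the scatter. For compound 3 the estimate is 15000 nM, within 6000 nM to 40000 nM.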

Compound 3, half-maximal inhibitory concentration: 5890 nM
The estimate for compound 3 lay 2.5-fold (0.41 log units) above the measured number; measured number below the stated range.
By their numbers in this assay, from the lowest: compounds 3 and 2 (each within the scatter of the next); then compound 1.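

In this assay the change from 6-chloro-1,3-benzothiazol-2-yl to 6-methoxy-1,3-benzothiazol-2-yl gives a 1.5-fold lower number from compound 2 to compound 3 (0.17 log units; within the scatter) and so does not separate chloro from methoxy at this position. Within the data shown here, the same swap made elsewhere on the shared core gives a 3.6-fold lower number from compound 1 to compound 3 (0.56 log units; beyond the scatter) and is the only one of the two steps beyond the scatter, so in this pair of steps the outcome varies with the site. No supporting data bear on the reason for this difference.

Going by these compounds, whether an amine, a hydroxyl or a longer alkoxy chain at the fused-ring position would move the number remains open. Also open, on these data alone, is whether the swap behaves the same way on a different core.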